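Carboxyazetidine Replaced by Hydroxypyrrolidine

The compounds below may be only part of what the source reports. "The series", "measured", "known", "first", "only" and "open" are said of these compounds alone.

Measured in a functional assay on MC-38 cells (Mus musculus) for antiproliferative activity, read by CCK-8 assay, with a stated time of 48 h; a higher number here means a weaker inhibitor, a lower number a stronger inhibitor:
Compound 1 `COc1ccc(/C=C\c2cc(OC)c(OC)c(OC)c2)cc1OCc1ccc(CN2CCCC[C@H]2C(=O)O)cc1`: > 10000 nM
Compound 2 `COc1ccc(/C=C\c2cc(OC)c(OC)c(OC)c2)cc1OCc1ccc(CN2CC[C@H](C(=O)O)C2)cc1`: > 10000 nM
Compound 3 `COc1ccc(/C=C\c2cc(OC)c(OC)c(OC)c2)cc1OCc1ccc(CN2CC(C(=O)O)C2)cc1`: > 10000 nM

Compound 3 gives > 10000 nM, which is a limit and not a number. All three compounds stand at the limit of > 10000 nM in this assay, at which 3 of the 3 values shown sit.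

Compound 4 `COc1ccc(/C=C\c2cc(OC)c(OC)c(OC)c2)cc1OCc1ccc(CN2CC[C@H](O)C2)cc1` differs from compound 3 in one place: 3-hydroxypyrrolidin-1-yl in place of 3-carboxyazetidin-1-yl on a saturated chain carbon bound to an aromatic carbon. The measured steps that bear on this change are a step that the two limits leave unreadable from compound 1 to compound 3, a step that the two limits leave unreadable from compound 2 to compound 3 and a step that the two limits leave unreadable from compound 1 to compound 2. All three keep the carboxy group, and none yields a size.

Compound 4 alone carries no carboxy group, so a step towards stronger inhibition is expected in this assay, though its size is uncertain. The estimated change is an at least 20-fold lower number from compound 3 to compound 4 (1.30 log units; beyond the scatter). Compound 4 is expected at 500 nM, within a range of 30 nM to 10000 nM.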

Compound 4, half-maximal inhibitory concentration: 7200 nM
Compound 4: the middle estimate sits 14-fold (1.16 log units) below what was measured, and the stated range covers the measured number.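

In this assay compound 4 is the only one of the four to give a number and not a limit, 7200 nM, so a reading first appears with hydroxy in place of carboxy. Its steps can be read only as floors: an at least 1.3-fold lower number from compound 3 to compound 4 (0.14 log units; that floor lies within the scatter), an at least 1.3-fold lower number from compound 2 to compound 4 (0.14 log units; that floor lies within the scatter) and an at least 1.3-fold lower number from compound 1 to compound 4 (0.14 log units; that floor lies within the scatter). The compounds that keep the carboxy group all rest at a limit of the assay: the limit of > 10000 nM in this assay, at which 3 of the 4 values shown sit.

As far as these compounds go, whether the number depends on the hydroxy group itself or only on the loss of the carboxy group stays open. So does how an amine or a methoxy group on that saturated ring carbon would read.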